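Notes on the step from compound 2 to compound 4

The source may hold more compounds than are shown below. What is called first, only, known or untested is meant among the compounds shown, and "the series" means these compounds.

Values from a physicochemical assay for lipophilicity, read by HPLC, at pH 7.5 (a higher number here means a more lipophilic compound, a lower number a more polar compound), follow
compound 1 `CCOc1ccccc1-c1ccc(-c2nc3cnccc3cc2C#N)cc1` gives 3.8
compound 2 `CC[C@@H](Nc1c(C#N)c(-c2ccc(-c3ncccc3C)cc2)nc2cnccc12)C(N)=O` gives 2
compound 3 `CCOc1ccccc1-c1ccc(-c2nc3cnccc3c(N[C@H](CC)C(=O)NS(=O)(=O)C3CC3)c2C#N)cc1` gives 2.3

Compound 2 at 2 and compound 3 at 2.3 lie within the scatter of each other at the low end of the three numbers. Compound 1 at 3.8 stands beyond the scatter above compound 2.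

Compound 4 `CC[C@@H](Nc1c(C#N)c(-c2ccc(-c3ccccc3N(C)C)cc2)nc2cnccc12)C(N)=O` has not yet been measured. It carries 2-(dimethylamino)phenyl in place of 3-methylpyridin-2-yl on an aromatic carbon of a six-membered aromatic ring of carbon only, para to a large group (2-(dimethylamino)phenyl in place of 3-methylpyridin-2-yl on an aromatic carbon).

Going by the values given here, no two measured compounds differ in one place only, so the series offers no direct step to carry over and the expectation below is a loose one. On the change as counted, a step upward in this assay and beyond the scatter is expected (a number 0.90 log units higher from compound 2 to compound 4 (beyond the scatter)). Compound 1 at 3.8 marks the top of the measured numbers, and the expectation stays under it. In this assay the estimated value for compound 4 is 2.9 with an expected range of (2.4 to 3.4).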

Compound 4, distribution coefficient: 3.2
For compound 4 the middle estimate is 0.30 log units below the measured one; the range from low to high includes it.
By their numbers in this assay, from the lowest: compounds 2 and 3 (each within the scatter of the next); then compound 4; then compound 1.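

In this assay, going by these compounds alone, 2-(dimethylamino)phenyl in place of 3-methylpyridin-2-yl, on an aromatic carbon of a six-membered aromatic ring of carbon only and para to a large group, gives a number 1.20 log units higher from compound 2 to compound 4 (beyond the scatter), the first step that can be read at a single place and a large one. The step comes with a six-membered aromatic ring of carbon only in place of one with 1 hetero atom and with 9 heavy atoms in place of 7, while the counted hydrogen-bond donors, hydrogen-bond acceptors and net charge stay the same, so this position is one where an exchange of aryl groups moves the number well beyond the scatter. Nothing measured here bears on what lies behind the size of this step.

Within the data shown here, the single step does not divide its size between the change of ring and the dimethylamino group, and unsubstituted phenyl at this place would be the group to separate the two. Also open, from the compounds shown here alone, is how a carboxylic acid or a piperidine at the same place would stand against compound 2 and compound 4 in this assay.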